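The source may hold more compounds than are shown below. What is called first, only, known or untested is meant among the compounds shown, and "the series" means these compounds.

In a functional assay on HT-29 cells (Homo sapiens) for inhibition, read by MTT assay, with a stated time of 48 h (on this read-out lower numbers stand for stronger inhibition and higher numbers for weaker inhibition), compound 1 `COc1cc(-c2nnc(SC)n2-c2ccc(N(C)C)cc2)cc(OC)c1OC` gives only a limit, > 60000 nM. Within the data shown here, compound 2 `COc1cc(-c2nnc(SCc3ccc(C)cc3)n2-c2ccc(N(C)C)cc2)cc(OC)c1OC` gives 27500 nM, the only actual number so far. Among the measured compounds shown here, the one measured step, an at least 2.1-fold lower number from compound 1 to compound 2 (0.33 log units; beyond the scatter), came with 4-methylphenyl in place of hydrogen on a saturated chain carbon bound to a sulfur. Compound 3 `CCOC(=O)CSc1nnc(-c2cc(OC)c(OC)c(OC)c2)n1-c1ccc(N(C)C)cc1` has ethoxycarbonyl in place of that 4-methylphenyl: ethoxycarbonyl in place of 4-methylphenyl on a saturated chain carbon bound to a sulfur. With the 4-methylphenyl gone, the gain seen in an at least 2.1-fold lower number from compound 1 to compound 2 (0.33 log units; beyond the scatter) is expected to be largely lost, so weaker inhibition is expected, of similar size in reverse: a 2.2-fold higher number from compound 2 to compound 3 (0.34 log units; beyond the scatter). For compound 3 the estimate is 60000 nM, with an expected range of 30000 nM to 120000 nM.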

Compound 3, half-maximal inhibitory concentration: 28800 nM
Compound 3: middle estimate off by 2.1-fold (0.32 log units), on the high side, outside the stated range (below it).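

In this assay, the gain over hydrogen on a saturated chain carbon bound to a sulfur does not depend on the 4-methylphenyl ring: ethoxycarbonyl, which has no ring, gives a 1.0-fold higher number from compound 2 to compound 3 (0.02 log units; within the scatter). Against hydrogen, it gives an at least 2.0-fold lower number from compound 1 to compound 3 (0.31 log units; beyond the scatter). As far as these compounds go, the true size of that step stays unknown because compound 1 gives only a limit: the limit of > 60000 nM in this assay, at which 1 of the 3 values shown sits. From the compounds shown here alone, whether a carboxylic acid, an amine or a longer chain at this place would give a lower number remains open.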